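Bromo on the benzyl end of the series

The source may report more compounds than this note shows. Statements on the series, on what has been measured and on what is new or still open speak of the compounds shown alone.

Compound 3 (`COc1cc(OC)c2c(c1)C(C(O)c1ccc(OCc3ccccc3)cc1)OC2=O`) gives > 40000 nM in an ADME assay on RAW264.7 cells (Mus musculus) for cytotoxicity, read by MTT assay, with a stated time of 24 h, in the absence of a further agent (a lower number here means a stronger inhibitor, a higher number a weaker inhibitor), as a limit and not a number. Compound 1 (`CCCOc1ccc(C(O)C2OC(=O)c3c(OC)cc(OC)cc32)cc1`) gives > 40000 nM in this assay as a limit as well. Compound 2 (`COCCOc1ccc(C(O)C2OC(=O)c3c(OC)cc(OC)cc32)cc1`) gives > 40000 nM in this assay as another limit. Going by the values given here, compound 3 therefore has no numerical position, and the record so far reads the limit of > 40000 nM in this assay, at which 3 of the 3 values shown sit, with no compound against it.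

Compound 4 (`COc1cc(OC)c2c(c1)C(C(O)c1ccc(OCc3ccc(Br)cc3)cc1)OC2=O`) has bromo in place of hydrogen on an aromatic carbon, para to a large group, so that benzyloxy becomes (4-bromobenzyl)oxy.

The nearest measured changes are in the same ether chain: a step that the two limits leave unreadable from compound 1 to compound 3 and a step that the two limits leave unreadable from compound 2 to compound 3 and also a step that the two limits leave unreadable from compound 1 to compound 2 for the shorter chains. None of them gives a size, and none places a group on this aromatic ring.

On the strength of a step that the two limits leave unreadable from compound 1 to compound 3 no step beyond the scatter is expected in either direction, and the estimated a number no higher from compound 3 to compound 4 (the limit leaves the size open) carries no readable trend. In this assay the estimate for compound 4 is 40000 nM with an expected range of 15000 nM to 80000 nM and another report as a limit is the likeliest outcome.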

Compound 4, half-maximal inhibitory concentration: > 40000 nM
Compound 4: no number, only a limit (the forecaster's own chance of this, stated with the estimate: 75%); the middle value sits exactly at the limit.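

Compound 4 gives > 40000 nM in this assay, a limit and not a number. No step from compound 1, compound 2 or compound 3 to compound 4 can be read, and the series still rests on one limit: the limit of > 40000 nM in this assay, at which 4 of the 4 values shown sit.

The compounds shown leave open whether bromo or any change in the ether chain alters cytotoxicity at all.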